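The source may report more compounds than this note shows. Statements on the series, on what has been measured and on what is new or still open speak of the compounds shown alone.

Measured so far:
- compound 1, `CCOCCOC(=O)C(=O)Nc1nc(-c2cc(Cl)no2)cs1`, in a functional assay on the whole organism with Rattus norvegicus as the target (on this read-out lower numbers stand for an effect already at smaller amounts and higher numbers for an effect only at larger amounts of compound), gives > 30 mg/kg, which is a limit of the assay and not a number.
- compound 2, `CCOCCOC(=O)C(=O)Nc1nc(-c2cc(OC)no2)cs1`, in this assay gives 11 mg/kg.
- compound 3, `CCOCCOC(=O)C(=O)Nc1nc(-c2cc(C)no2)cs1`, in this assay gives 1.3 mg/kg.

Compound 3 has the lowest number of the two that are known; the nearest is compound 2, and the step of an 8.5-fold lower number from compound 2 to compound 3 (0.93 log units; beyond the scatter) is beyond the scatter. Compound 1 sits only at a limit, (the limit of > 30 mg/kg in this assay, at which 1 of the 3 values shown sits).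

Compound 4, `CCOCCOC(=O)C(=O)Nc1nc(-c2cc(C(=O)OCC)no2)cs1`, has not yet been measured in this assay. Its difference from compound 3 is ethoxycarbonyl in place of methyl on an aromatic carbon.

Among the measured compounds shown here, two measured steps bear on this place on the ring. Both an at least 23-fold lower number from compound 1 to compound 3 (1.36 log units; beyond the scatter) and an 8.5-fold lower number from compound 2 to compound 3 (0.93 log units; beyond the scatter) show that the methyl gives the lowest number among the three groups tried there, while chloro leaves only a limit and methoxy gives a clearly higher number. The ethoxycarbonyl is a group of a different kind from any of these three, so the size of its effect is not fixed by the measured steps, but since every change away from methyl that has been seen raised the number, a higher number is expected for compound 4 as well. The step expected is a 6.2-fold higher number from compound 3 to compound 4 (0.79 log units; beyond the scatter), beyond the scatter. Compound 4 is therefore estimated at 8 mg/kg, with a range from 2 mg/kg to 30 mg/kg.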

Compound 4, dose for half-maximal effect: 1.9 mg/kg
Compound 4: the middle estimate sits 4.2-fold (0.62 log units) above what was measured, outside the stated range (below it).
By their numbers in this assay, from the lowest: compounds 3 and 4 (each within the scatter of the next); then compound 2. At a limit, above all of these: compound 1.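

In this assay, the step of a 1.5-fold higher number from compound 3 to compound 4 (0.16 log units; within the scatter) shows that this place, next to the ring nitrogen, accepts the much larger ethoxycarbonyl in place of methyl with no change beyond the scatter, so a small alkyl group is not needed here. Compound 4 therefore goes against the earlier picture, in which every change away from methyl raised the number: that picture now holds only for methoxy and chloro, and the step of a 5.8-fold lower number from compound 2 to compound 4 (0.76 log units; beyond the scatter) shows that two groups containing oxygen can behave very differently at this place. The step of an at least 15-fold lower number from compound 1 to compound 4 (1.19 log units; beyond the scatter) points the same way, but it is only a bound, since compound 1 stands at a limit of the assay and not at a number: the limit of > 30 mg/kg in this assay, at which 1 of the 4 values shown sits.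

Going by these compounds, it remains open whether the low number depends on the ester as a whole, which a carboxylic acid, a primary amide or a longer alkyl chain at this place would help to test. With only this assay to go on, the compounds shown also cannot explain why methoxy and ethoxycarbonyl differ.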